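Hydroxy to Methylamino: Expected Solubility of Compound 4

The source may report more compounds than this note shows. Statements on the series, on what has been measured and on what is new or still open speak of the compounds shown alone.

compound 1, `COc1ccc(-c2cc(-c3ccc(S(C)(=O)=O)cc3)cnc2O)cn1`: 25 ug/mL
compound 2, `COc1ccc(-c2cc(-c3ccc(S(C)(=O)=O)cc3)ccc2N)cn1`: 6.3 ug/mL
compound 3, `COc1ccc(-c2nc(-c3ccc(S(C)(=O)=O)cc3)cnc2N)cn1`: 6.3 ug/mL

Of the compounds shown here, three have been measured in a physicochemical assay for solubility, measured as kinetic solubility, at pH 6.5; on this read-out lower numbers stand for lower solubility and higher numbers for higher solubility. Compound 1 stands highest of the three with 25 ug/mL. Compound 2 gives 6.3 ug/mL, a number that lies beyond the scatter below compound 1, and compound 3 gives 6.3 ug/mL, the same distance below compound 1. Among the compounds with values here, no two of the measured compounds differ in one place only, so no single measured step is available to guide the next change.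

Within the data shown here, compound 4, `CNc1ncc(-c2ccc(S(C)(=O)=O)cc2)cc1-c1ccc(OC)nc1`, is the one compound not yet measured. It differs from compound 1 in one place: methylamino in place of hydroxy on an aromatic carbon. The two measured compounds that do not carry the hydroxy of compound 1 both sit well below it, and compound 4 also gives up that hydroxy. On that ground, and on the observation that compound 1 already holds the top of a narrow range, a downward step is the expectation here, one that may well reach beyond the scatter, though the size is uncertain. The step from compound 1 to compound 4 is estimated as a 2.8-fold lower number from compound 1 to compound 4 (0.44 log units; beyond the scatter). For compound 4 the estimate in this assay is 9 ug/mL, within a range from 3 ug/mL to 25 ug/mL.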

Compound 4, solubility: 12.5 ug/mL
The estimate for compound 4 lay 1.4-fold (0.14 log units) below the measured number, within the range that was stated.
By their numbers in this assay, from the lowest: compounds 2, 3, 4 and 1 (each within the scatter of the next, the first and the last beyond it).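

Within the data shown here, the earlier compounds offered no step that changed one place only, so this is the first direct reading of a single change. In this assay, putting methylamino in place of hydroxy on the aromatic carbon next to the ring nitrogen gives a 2.0-fold lower number from compound 1 to compound 4 (0.30 log units; within the scatter), so on this read-out the two groups cannot be told apart at this position, and the larger methylamino, with its extra heavy atom, leaves no change that stands clear of the usual scatter. The exchange keeps the same count of hydrogen-bond donors and acceptors and adds no ring or net charge, but no measurement at hand bears on why the two groups read alike.

The compounds shown leave open whether this position stays as undemanding with a group that has no hydrogen-bond donor, such as dimethylamino or methoxy, or with a longer chain such as ethylamino or a carboxylic acid. They also leave open whether a wider set of groups here would produce a step that clears the scatter in either direction, since a single step within it cannot define how far the position can be pushed.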